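The compounds below may be only part of what the source reports. "The series", "measured", "known", "first", "only" and "open" are said of these compounds alone.

Measured compounds in an ADME assay on cells (Hepatocyte, Rattus norvegicus) for metabolic stability; on this read-out lower numbers stand for slow clearance and higher numbers for fast clearance:

Compound 1, `CC(C)n1nc(-c2ccnc3[nH]c(C4CCN(CC(=O)N(C)C)CC4)cc23)ccc1=O`: compound 1 gives 3.1 uL/min.
Compound 2, `CC(=O)N1CCC(c2cc3c(-c4ccc(=O)n(C(C)C)c4)ccnc3[nH]2)CC1`: compound 2 gives 2.8 uL/min.
Compound 3, `CC(C)n1cc(-c2ccnc3[nH]c(C4CCN(CC(=O)N5CCCC5)CC4)cc23)ccc1=O`: compound 3 gives 5.4 uL/min.

Compound 1 stands second of the three numbers in this assay; its gap to compound 2 and its gap to compound 3 both lie within the usual scatter, so the three compounds read as indistinguishable on this read-out. Among the compounds with values here, the only single-point step among them, a 1.9-fold higher number from compound 2 to compound 3 (0.29 log units; within the scatter), is also within the scatter.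

Compound 4, `CCn1cc(-c2ccnc3[nH]c(C4CCN(CC(=O)N(C)C)CC4)cc23)ccc1=O`, has not yet been measured. It differs from compound 1 in one place: a group of 9 heavy atoms (7 carbon, 1 nitrogen, 1 oxygen; one six-membered aromatic ring with 1 hetero atom) in place of a group of 10 heavy atoms (7 carbon, 2 nitrogen, 1 oxygen; one six-membered aromatic ring with 2 hetero atoms), on an aromatic carbon. The position involved is on an aromatic carbon of the core, opposite the ring nitrogen.

Within the data shown here, none of the measured steps touches this part of the core; the one measured step concerns the substituent on the amine nitrogen in the ring, and it was within the scatter. Compound 3 shares with compound 4 a six-membered aromatic ring with one hetero atom at that place but differs from compound 1 elsewhere as well, so its value and that of compound 1 can only be read side by side. Nothing in the data points to a step beyond the scatter.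

Compound 4 is therefore expected to give about 3.5 uL/min in this assay, within 1.6 uL/min to 7.5 uL/min, the expected step being a 1.1-fold higher number from compound 1 to compound 4 (0.05 log units; within the scatter).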

Compound 4, intrinsic clearance in a liver preparation (reported as CLH), per the amount of preparation that the assay uses in the Hepatocyte assay: < 1 uL/min
Compound 4: only a limit was reported (the forecaster's own chance of this, stated with the estimate: 10%); at least 3.5-fold (0.54 log units) between middle value and limit.
By their numbers in the Hepatocyte assay, from the lowest: compounds 2, 1 and 3 (each within the scatter of the next). At a limit, below all of these: compound 4.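

In the Hepatocyte assay the exchange of the ring with 2 hetero atoms for the ring with 1 hetero atom, on the aromatic carbon opposite the ring nitrogen of the core, gives an at least 3.1-fold lower number from compound 1 to compound 4 (0.49 log units; beyond the scatter), so this position can move clearance beyond the scatter, which no earlier comparison showed. For compound 4 the reading of < 1 uL/min is a limit of the assay and not a number, so the step has a minimum size and no known full size. In a physicochemical assay for lipophilicity, using the shake flask method, measured as octanol-water partition, at pH 7.4 (on this read-out lower numbers stand for lower lipophilicity and higher numbers for higher lipophilicity), compound 1 gives 2 and compound 4 gives 1.2, so the distribution coefficient and clearance both go down across this one pair.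

The exchange joins two differences, the hetero atom count of the ring and isopropyl against ethyl on its nitrogen, and the compounds shown do not separate them. One pair also cannot tell whether clearance follows the distribution coefficient in this series, or how a methyl or cyclopropyl on that ring nitrogen would read in the Hepatocyte assay.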